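From trifluoromethyl to amino: compound 3 to compound 4

This account rests on a few compounds, and the source may have more. Where it says the series, first, only, none or still open, it means among the compounds named here.

Measured in a functional assay on L5178Y cells (Mus musculus) for inhibition, read by MTT assay, with a stated time of 24 h (a higher number here means a weaker inhibitor, a lower number a stronger inhibitor), each value a limit and not a number:
compound 1 `COc1cccc(/C=N/N=C2\C[C@@H](c3ccc(O)cc3)Oc3cc(OC)cc(O)c32)c1` gives >= 11300 nM
compound 2 `COc1cc(O)c2c(c1)O[C@H](c1ccc(O)cc1)C/C2=N\N` gives >= 11300 nM
compound 3 `COc1cc(O)c2c(c1)O[C@H](c1ccc(O)cc1)C/C2=N\NC(=O)c1ccc(C(F)(F)F)cc1` gives >= 11300 nM

Compound 3 stands at >= 11300 nM, which is a limit and not a number. The other two measured compounds give no better reference point, since the set as a whole reads (the limit of >= 11300 nM in this assay, at which 3 of the 3 values shown sit).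

Compound 4 `COc1cc(O)c2c(c1)O[C@H](c1ccc(O)cc1)C/C2=N\NC(=O)c1ccc(N)cc1` puts amino in place of trifluoromethyl on an aromatic carbon, para to a large group, so that 4-(trifluoromethyl)phenyl becomes 4-aminophenyl: amino in place of trifluoromethyl on an aromatic carbon.

Among the compounds with values here, the only measured step in the set is a step that the two limits leave unreadable from compound 1 to compound 2. That step lies at a different place, on a double-bonded nitrogen, and its size cannot be read. Within the data shown here, no measured step covers the aromatic carbon that changes here, so the data give no sign of a shift in either direction.

Resting on (the limit of >= 11300 nM in this assay, at which 3 of the 3 values shown sit), no step beyond the scatter is expected in this assay, and a further limit is the likeliest report. The expected size is a step that the limit leaves unreadable from compound 3 to compound 4. The estimate for compound 4 is 14000 nM, with an expected range from 7000 nM to 30000 nM.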

Compound 4, half-maximal inhibitory concentration: >= 11300 nM
Compound 4 was reported as a limit (the forecaster's own chance of this, stated with the estimate: 80%); the middle value does not contradict the limit.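

In this assay compound 4 gives >= 11300 nM, which is a limit and not a number. No step from compound 1, compound 2 or compound 3 to compound 4 can be read, as all four values sit at one limit: the limit of >= 11300 nM in this assay, at which 4 of the 4 values shown sit.

The compounds shown leave open whether any change on the shared core gives a readable value in this assay.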